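Compound 2 to its 2-iodophenyl analogue, compound 4

A few compounds are considered here, and "the series" means these few. Any claim that something is new, unique, unknown or untested is made for them only; others in the source may bear on it.

In a functional assay on A549 cells (Homo sapiens) for antiproliferative activity, read by MTT assay, with a stated time of 48 h (a higher number here means a weaker inhibitor, a lower number a stronger inhibitor), compound 1 (`c1ccc(-c2nnc(-c3cn4ccccc4n3)o2)cc1`) gives 23400 nM and compound 2 (`Cc1cccn2cc(-c3nnc(-c4ccccc4)o3)nc12`) gives 23400 nM on the same read-out. Compound 2 is therefore level with compound 1, and methyl in place of hydrogen on an aromatic carbon accounts for the whole structural difference (no change at the digits printed from compound 1 to compound 2 (within the scatter)). Compound 3 (`Cc1cccn2cc(-c3nnc(-c4ccc(N(C)C)cc4)o3)nc12`), with dimethylamino in place of hydrogen on an aromatic carbon, gives 12300 nM and stays within the scatter of compound 2 (a 1.9-fold lower number from compound 2 to compound 3 (0.28 log units; within the scatter)).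

Compound 4 (`Cc1cccn2cc(-c3nnc(-c4ccccc4I)o3)nc12`) takes iodo in place of hydrogen on an aromatic carbon, ortho to a large group (iodo in place of hydrogen on an aromatic carbon), which reads as phenyl to 2-iodophenyl. Among the measured compounds shown here, no measured compound carries iodo, so the evidence is indirect. For the measured compounds named here, the closest precedent is compound 3, also a replacement of hydrogen on an aromatic carbon, and its step stayed within the scatter (a 1.9-fold lower number from compound 2 to compound 3 (0.28 log units; within the scatter)). Neither measured step leaves the scatter, so no step beyond it is expected, and no direction can be argued. The estimated step is small (a 1.3-fold lower number from compound 2 to compound 4 (0.11 log units; within the scatter)). Compound 4 is expected in this assay at 18000 nM (estimated range 8000 nM to 38000 nM).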

Compound 4, half-maximal inhibitory concentration: 33400 nM
Estimate against measurement, compound 4: 1.9-fold (0.27 log units) below; measured number inside the range.
By their numbers in this assay, from the lowest: compounds 3, 1, 2 and 4 (each within the scatter of the next, the first and the last beyond it).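

Iodo on an aromatic carbon of the six-membered aromatic ring of carbon only, ortho to a large group, is the first replacement at this place, and in this assay it gives a 1.4-fold higher number from compound 2 to compound 4 (0.15 log units; within the scatter). A single iodine atom at this place therefore does not take the number out of the scatter, and phenyl to 2-iodophenyl can be read as a change without a measurable effect on this read-out. With no change at the digits printed from compound 1 to compound 2 (within the scatter) and a 1.9-fold lower number from compound 2 to compound 3 (0.28 log units; within the scatter), this makes three replacements of hydrogen on an aromatic carbon in the series, all within the scatter, and no evidence bearing on the result of compound 4 is at hand.

Open, from the compounds shown here alone, is whether another group at this same place, such as fluoro, an amine or a carboxylic acid, would give a step beyond the scatter. Also open, going by these compounds, is whether iodo at other places on the same ring, or on the core of compound 1 without the methyl, would read as it does in compound 4.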